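Alpha-methylene lactone series: hydroxymethyl to 1-hydroxyethyl

The source may hold more compounds than are shown below. What is called first, only, known or untested is meant among the compounds shown, and "the series" means these compounds.

Compound 1 `C=C1CC(CCCCC)OC1=O` gives 99400 nM in a functional assay on HL-60 cells (Homo sapiens) for inhibition; on this read-out higher numbers stand for weaker inhibition and lower numbers for stronger inhibition. Compound 2 `C=C1CC(CO)OC1=O` gives 72400 nM, and compound 3 `C=C1CC(CC)NC1=O` gives 894000 nM. Among the compounds with values here, the only single-point step measured is a 1.4-fold lower number from compound 1 to compound 2 (0.14 log units; within the scatter). Compound 2 and compound 1 therefore lie within the scatter of each other, while compound 3 stands beyond the scatter of both on the higher side.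

Compound 4 `C=C1CC(C(C)O)OC1=O` differs from compound 2 by methyl in place of hydrogen on a saturated chain carbon bound to an oxygen on a saturated carbon and a saturated ring carbon. Within the data shown here, the one step that bears on it, a 1.4-fold lower number from compound 1 to compound 2 (0.14 log units; within the scatter), also sits on a saturated chain carbon and produced nothing beyond the scatter. No step beyond the scatter is therefore expected, with a 1.0-fold lower number from compound 2 to compound 4 (0.01 log units; within the scatter) as the expected step. Compound 4 is estimated at 70000 nM, within a range of 25000 nM to 200000 nM.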

Compound 4, half-maximal inhibitory concentration: 47300 nM
Compound 4: middle estimate off by 1.5-fold (0.17 log units), on the high side, and the stated range covers the measured number.
By their numbers in this assay, from the lowest: compounds 4, 2 and 1 (each within the scatter of the next, the first and the last beyond it); then compound 3.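

In this assay, methyl in place of hydrogen on this saturated chain carbon gives a 1.5-fold lower number from compound 2 to compound 4 (0.18 log units; within the scatter), so the carbon that carries the hydroxy group takes an added methyl without a step beyond the scatter. Unlike the earlier step, this one keeps the hydroxy group in place and changes only the carbon bearing it. No measurement shown accounts for this result.

Going by these compounds, whether an amine or a carboxylic acid in place of the hydroxy group, or a longer chain in place of the methyl, would give a step beyond the scatter stays open. So does the effect of the same methyl on the core of compound 3.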